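A trifluoromethylphenyl amide tested in the cell assay

The source may hold more compounds than are shown below. What is called first, only, known or untested is meant among the compounds shown, and "the series" means these compounds.

Compound 3 `CSc1ccccc1C(=O)Nc1sc2c(c1C(N)=O)CCN(C(=S)Nc1ccccc1Cl)C2` holds the highest number of the three measured compounds in a functional assay on HL-60 cells (Homo sapiens) for antiproliferative activity, with a stated time of 24 h (a higher number here means a weaker inhibitor, a lower number a stronger inhibitor), giving 30500 nM. Its nearest neighbour is compound 2 `Cc1ccccc1C(=O)Nc1sc2c(c1C(N)=O)CCN(C(=S)Nc1ccccc1Cl)C2`, which in this assay gives 20900 nM; the step of a 1.5-fold higher number from compound 2 to compound 3 (0.16 log units; within the scatter) stays within the scatter. Compound 1 `NC(=O)c1c(NC(=O)c2ccccc2)sc2c1CCN(C(=S)Nc1ccccc1Cl)C2` gives 13800 nM in this assay, and the step of a 2.2-fold higher number from compound 1 to compound 3 (0.34 log units; beyond the scatter) is modest but beyond the scatter. The step of a 1.5-fold higher number from compound 1 to compound 2 (0.18 log units; within the scatter) is within the scatter.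

Compound 4 `NC(=O)c1c(NC(=O)c2ccc(C(F)(F)F)cc2)sc2c1CCN(C(=S)Nc1ccccc1Cl)C2` is not yet measured. It differs from compound 3 by 4-(trifluoromethyl)phenyl in place of 2-(methylsulfanyl)phenyl on a carbonyl carbon. Among the compounds with values here, none of the measured steps swaps the phenyl ring for one carrying a trifluoromethyl group, so no step bears directly on this change; the three steps only show that adding either group to the unsubstituted phenyl of compound 1 moved the number upward, by a small or modest amount. Compound 4 is therefore expected to land near the measured spread, with a step of a 1.4-fold lower number from compound 3 to compound 4 (0.14 log units; within the scatter) that is not expected to go beyond the scatter. For compound 4 the estimated value in this assay is 22000 nM, with a range from 8000 nM to 60000 nM.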

Compound 4, half-maximal inhibitory concentration: 36100 nM
For compound 4 the middle estimate is 1.6-fold (0.22 log units) below the measured one; low and high end bracket the measured number.
By their numbers in this assay, from the lowest: compounds 1, 2, 3 and 4 (each within the scatter of the next, the first and the last beyond it).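

In this assay, placing trifluoromethyl on the phenyl ring of compound 1 gives a 2.6-fold higher number from compound 1 to compound 4 (0.42 log units; beyond the scatter) and thereby a second substituent, after the methylsulfanyl of compound 3, whose step from the unsubstituted amide passes the scatter, while compound 2 goes against any such pattern. The ring attached to this carbonyl carbon also tolerates a change of both group and printed place without a readable difference, with a 1.2-fold higher number from compound 3 to compound 4 (0.07 log units; within the scatter) for the exchange of 2-(methylsulfanyl)phenyl and a 1.7-fold higher number from compound 2 to compound 4 (0.24 log units; within the scatter) for the exchange of 2-methylphenyl. No measurement offered here accounts for these values. The compounds shown leave open whether the group or its place on the ring sets the number, and whether an amine or a carboxylic acid on this phenyl ring would bring it under that of compound 1.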